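Styryl sulfone anilines: chloro scan and a new analogue

A few compounds are considered here, and "the series" means these few. Any claim that something is new, unique, unknown or untested is made for them only; others in the source may bear on it.

Measured compounds:
- compound 1 `O=S(=O)(/C=C/c1ccc(F)cc1)Cc1ccc(Nc2ncnc3ccccc23)cc1`: 5000 nM
- compound 2 `O=S(=O)(/C=C/c1ccc(Cl)cc1Cl)Cc1ccc(Nc2ncnc3ccccc23)cc1`: 2000 nM
- compound 3 `O=S(=O)(/C=C/c1ccc(F)cc1Cl)Cc1ccc(Nc2ncnc3ccccc23)cc1`: 100000 nM

The three measured compounds share one core and differ only in the aryl group at the end of the ethenyl sulfone. In a functional assay on UACC-62 cells (Homo sapiens) (on this read-out lower numbers stand for stronger inhibition of growth and higher numbers for weaker inhibition of growth), compound 2 gives 2000 nM, the lowest number of the three, and its steps to compound 1 and compound 3 are both beyond the scatter. Replacing the aryl group of compound 1, (2,4-dichlorophenyl in place of 4-fluorophenyl on a double-bonded chain carbon bound to a double-bonded chain carbon), gives a 2.5-fold lower number from compound 1 to compound 2 (0.40 log units; beyond the scatter). Adding a chloro group, (chloro in place of hydrogen on an aromatic carbon), gives a 20-fold higher number from compound 1 to compound 3 (1.30 log units; beyond the scatter), a large loss.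

Compound 4 `O=S(=O)(/C=C/c1ccc(Cl)cc1Cl)Cc1ccc(Nc2ncnc3cc(Cl)ccc23)cc1` is not yet measured. It is made from compound 2 by the same kind of change as from compound 1 to compound 3: chloro in place of hydrogen on an aromatic carbon. The place differs, though: in compound 3 the new chloro sits ortho to a large group and meta to a fluoro group on the aryl ring at the end of the chain, while in compound 4 it sits on the fused or bridged system of two rings of the core, meta and para to a fused ring. The earlier step is therefore only a loose guide. With one such step known and at a different place, a smaller change is expected, about a 1.5-fold higher number from compound 2 to compound 4 (0.18 log units; within the scatter), and compound 4 is estimated at 3000 nM, between 800 nM and 15000 nM.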

Compound 4, concentration for 50% growth inhibition: 32000 nM
Compound 4: the middle estimate sits 11-fold (1.03 log units) below what was measured; the whole stated range lies below it.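

In this assay, chloro in place of hydrogen on an aromatic carbon of the fused system gives a 16-fold higher number from compound 2 to compound 4 (1.20 log units; beyond the scatter), a large loss. Set beside the earlier step, the size of the loss carries over from one core to the other: the same change on two cores in this assay, a 20-fold higher number (1.30 log units; beyond the scatter) from compound 1 to compound 3 and a 16-fold higher number (1.20 log units; beyond the scatter) from compound 2 to compound 4, 1.3-fold (0.10 log units) apart, within the scatter of two such steps

For the compounds shown here, this agreement rests on only two steps, and the chloro sits at a different place in compound 3 and compound 4, so it shows a similar size of step and neither a shared origin nor a rule for other places or other cores.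

The compounds shown leave open whether the loss belongs to chloro itself or would also follow from another group at the same carbon of compound 2, such as a fluoro, a methoxy group or an amine. They also leave open how the same chloro on the fused system would act with the 4-fluorophenyl group of compound 1.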